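The source may hold more compounds than are shown below. What is called first, only, known or untested is meant among the compounds shown, and "the series" means these compounds.

Compound 3, `Brc1cc(Br)c2nnn(CC3CC3)c2c1`, gives 2.3 mL/min/g in an ADME assay on microsomes from liver (Rattus norvegicus, strain Wistar) for metabolic stability, tested at 2.5 uM (a higher number here means faster removal of the compound, a lower number slower removal), and stands highest of the three measured compounds. Compound 1, `Brc1cccc2c1nnn2CC1CC1`, gives 0.6 mL/min/g, and compound 2, `FC(F)(F)c1cc(Br)c2nnn(CC3CC3)c2c1`, gives 0.2 mL/min/g. The step of a 3.8-fold higher number from compound 1 to compound 3 (0.58 log units; beyond the scatter) and the step of a 12-fold higher number from compound 2 to compound 3 (1.06 log units; beyond the scatter) both show compound 3 well above its neighbours, while the step of a 3.0-fold lower number from compound 1 to compound 2 (0.48 log units; beyond the scatter) runs the other way.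

Compound 4, `Fc1cc(Br)c2nnn(CC3CC3)c2c1`, differs from compound 3 in one place: fluoro in place of bromo on an aromatic carbon. Going by the values given here, no measured step puts fluoro at this position, so the comparison rests on what hydrogen and trifluoromethyl gave there. Bromo in place of hydrogen raised the number, and trifluoromethyl in place of hydrogen lowered it; a fluoro group is expected to land between those two outcomes, so that the step of a 3.8-fold lower number from compound 3 to compound 4 (0.58 log units; beyond the scatter) is expected to fall clearly beyond the scatter, toward a lower number. On that basis compound 4 is estimated at 0.6 mL/min/g, within a range from 0.25 mL/min/g to 1.5 mL/min/g.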

Compound 4, intrinsic clearance in a liver preparation (reported as CLH), per the amount of preparation that the assay uses: 0.5 mL/min/g
Beside the measured number, compound 4's estimate is 1.2-fold (0.08 log units) above it; low and high end bracket the measured number.
By their numbers in this assay, from the lowest: compound 2; then compounds 4 and 1 (each within the scatter of the next); then compound 3.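

In this assay the step of a 1.2-fold lower number from compound 1 to compound 4 (0.08 log units; within the scatter) shows that fluoro, unlike bromo and trifluoromethyl, cannot be told apart from hydrogen at this aromatic carbon. The step of a 4.6-fold lower number from compound 3 to compound 4 (0.66 log units; beyond the scatter) therefore takes back the rise seen with bromo, while the step of a 2.5-fold higher number from compound 2 to compound 4 (0.40 log units; beyond the scatter) keeps fluoro clearly apart from trifluoromethyl, so the outcome at this place depends on which group enters and not merely on hydrogen being replaced. Nothing available here explains why these groups differ in this way.

From the compounds shown here alone, whether a nitrile, a methoxy group or an amine at this carbon would stay level with hydrogen and fluoro or move away from them remains open. Also open, going by these compounds, is whether the same order of groups would hold if another part of the shared core were changed.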